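A few compounds are considered here, and "the series" means these few. Any claim that something is new, unique, unknown or untested is made for them only; others in the source may bear on it.

Going by the values given here, compound 3 `CCc1ccc(-c2cn3ccnc3c(-c3ccc4ncn(Cc5ccccc5)c4c3)n2)cc1` gives 22.5% in a functional assay on SN12C cells (Homo sapiens) for inhibition, read by sulforhodamine B assay, with a stated time of 48 h, tested at 10 uM (a higher number here means more inhibition at the concentration tested (going by the name of the read-out), a lower number less inhibition), the highest of the three numbers measured so far. Among the compounds with values here, compound 1 `CC(=O)c1ccc(-c2cn3ccnc3c(-c3ccc4ncn(C5CCCCC5)c4c3)n2)cc1` gives 6.33% and compound 2 `FC(F)(F)c1cccc(-c2cn3ccnc3c(-c3ccc4ncn(C5CCCCC5)c4c3)n2)c1` gives 8.3% in this assay; the one step between them, a number 2 percentage points higher from compound 1 to compound 2 (within the scatter), exchanges the aryl group on the same aromatic carbon and stays within the scatter. Compound 4 `c1ccc(Cn2cnc3ccc(-c4nc(-c5cccc6ccccc56)cn5ccnc45)cc32)cc1` differs from compound 3 by naphthalen-1-yl in place of 4-ethylphenyl on an aromatic carbon. Within the data shown here, only that single measured step bears on this change, and it was small; compounds 1 and 2 also carry a different group on the shared core than compound 3, so no measured step reproduces the change cleanly. A step of a number 2.5 percentage points lower from compound 3 to compound 4 (within the scatter) is therefore expected, none beyond the scatter. Compound 4 is estimated at 20%, between 4% and 40%.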

Compound 4, a percentage reported as inhibition, at one concentration (the size of the read-out at that concentration, not a potency): 5.62%
Beside the measured number, compound 4's estimate is 14.4 percentage points above it; low and high end bracket the measured number.
By their numbers in this assay, from the lowest: compounds 4, 1 and 2 (each within the scatter of the next); then compound 3.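

The step to naphthalen-1-yl, a number 16.9 percentage points lower from compound 3 to compound 4 (beyond the scatter), shows that the aryl group on this aromatic carbon, next to the ring nitrogen, can shift the result in this assay beyond the scatter, which the earlier exchange, a number 2 percentage points higher from compound 1 to compound 2 (within the scatter), did not show. The entering group has two six-membered aromatic rings of carbon and the leaving group one, but this single pair cannot tie the drop to that count. No measured evidence accounts for the drop. Going by these compounds, whether the same exchange would matter with the other group carried by compounds 1 and 2 stays open. So does the effect of an amine or a carboxylic acid on the aryl ring here.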